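Swapping a sulfur-containing ring for a benzimidazole

This account rests on a few compounds, and the source may have more. Where it says the series, first, only, none or still open, it means among the compounds named here.

Three compounds share an amide built on a benzylic sulfonyl fragment. Compound 1 `O=C(NCc1ccc(S(=O)(=O)c2ccccc2)cc1)c1cc2ncccc2s1` is described in a functional assay on A2780 cells (Homo sapiens) for inhibition, read by sulforhodamine B assay, with a stated time of 72 h (on this read-out higher numbers stand for weaker inhibition and lower numbers for stronger inhibition), only by a limit, > 10000 nM, which is the limit of > 10000 nM in this assay, at which 1 of the 3 values shown sits. Compound 2 `O=C(NCc1ccc(S(=O)(=O)N2CCCCC2)cc1)c1cc2cnccc2s1` gives 1600 nM in this assay, the highest of the two numbers shown. Compound 3 `O=C(NCc1ccc(S(=O)(=O)c2ccccc2)cc1)c1ccc2nccn2c1` gives 13 nM. For the measured compounds named here, the one measured step that bears on the change at hand is an at least 760-fold lower number from compound 1 to compound 3 (2.88 log units; beyond the scatter), which exchanges a group containing sulfur for one of carbon and nitrogen only. Compound 4 `O=C(NCc1ccc(S(=O)(=O)N2CCCCC2)cc1)c1ccc2nc[nH]c2c1` makes a related change on compound 2: a group of 9 heavy atoms (7 carbon, 2 nitrogen; one five-membered aromatic ring with 2 hetero atoms, one six-membered aromatic ring of carbon only) in place of a group of 9 heavy atoms (7 carbon, 1 nitrogen, 1 sulfur; one five-membered aromatic ring with 1 hetero atom, one six-membered aromatic ring with 1 hetero atom), on a carbonyl carbon. Going by the values given here, the entering group differs from the one in compound 3, so a smaller step in the same direction is expected. Compound 4 is estimated at 150 nM, between 20 nM and 1000 nM. This means an expected 11-fold lower number from compound 2 to compound 4 (1.03 log units; beyond the scatter).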

Compound 4, half-maximal inhibitory concentration: > 10000 nM
Compound 4: only a limit was reported (the forecaster's own chance of this, stated with the estimate: 3%); middle value at least 66-fold (1.82 log units) from the limit.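

In this assay, putting 1H-benzimidazol-6-yl on the carbonyl carbon gives an at least 6.2-fold higher number from compound 2 to compound 4 (0.79 log units; beyond the scatter), so at this place, losing the sulfur-containing group does not by itself bring stronger inhibition. The large gain on reaching compound 3 therefore does not extend to every sulfur-free group, and it may depend on the entering group or on the rest of the molecule. Compound 4 is known only as a limit, not as a number: the limit of > 10000 nM in this assay, at which 2 of the 4 values shown sit.

As far as these compounds go, how far its true value lies past that limit stays open. Also open, from the compounds shown here alone, is whether a methyl group on the ring nitrogen of 1H-benzimidazol-6-yl, or the sulfonyl partner found in compound 3, would restore inhibition.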